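A few compounds are considered here, and "the series" means these few. Any claim that something is new, unique, unknown or untested is made for them only; others in the source may bear on it.

Compound 1 `O=C(O)CN1C(=O)/C(=C/c2nc3ccccc3n2Cc2ccc(F)cc2)SC1=S` and compound 2 `O=C(O)CN1C(=O)/C(=C/c2nc3ccccc3n2Cc2ccc(Cl)cc2)SC1=S` share one core, while compound 3 `Cc1ccc(Cn2c(/C=C3\SC(=S)N(CC(=O)O)C3=O)nc3cc(Cl)ccc32)cc1` and compound 4 `Cc1ccc(Cn2c(/C=C3\SC(=S)N(CC(=O)O)C3=O)nc3cc(F)ccc32)cc1` share another; the difference between the two cores is not broken down here. In a functional assay on A549 cells (Homo sapiens) for cytotoxicity, read by MTT assay, with a stated time of 48 h (a lower number here means a stronger inhibitor, a higher number a weaker inhibitor), compound 1 gives 3570 nM, compound 2 gives 17500 nM, and compound 3 gives 38600 nM. The change fluoro in place of chloro on an aromatic carbon made a step of a 4.9-fold lower number from compound 2 to compound 1 (0.69 log units; beyond the scatter). Compound 4 carries the same kind of change, (fluoro in place of chloro on an aromatic carbon), but the place differs: in the earlier pair the fluoro sits para to a large group, whereas in compound 4 it sits on a ring that is part of a fused system, meta and para to a fused ring. Because of a 4.9-fold lower number from compound 2 to compound 1 (0.69 log units; beyond the scatter), compound 4 is expected to give a lower number than compound 3, estimated at a step of a 2.6-fold lower number from compound 3 to compound 4 (0.41 log units; beyond the scatter), somewhat smaller given the different place. Compound 4 is therefore estimated at 15000 nM in this assay.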

Compound 4, half-maximal inhibitory concentration: 13800 nM
Compound 4: middle estimate off by 1.1-fold (0.04 log units), on the high side, within the range that was stated.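

In this assay, fluoro in place of chloro on an aromatic carbon gives a 2.8-fold lower number from compound 3 to compound 4 (0.45 log units; beyond the scatter), the same direction as on the other core, and the two steps do not differ beyond what repeated measurement allows: the same change on two cores in this assay, a 4.9-fold lower number (0.69 log units; beyond the scatter) from compound 2 to compound 1 and a 2.8-fold lower number (0.45 log units; beyond the scatter) from compound 3 to compound 4, 1.8-fold (0.24 log units) apart, within the scatter of two such steps The change thus carried over between these two cores, in direction and, within the scatter, in size, even though it stands at a different place in each. Two pairs in one assay do not show that it would hold on further cores, and they do not explain the lower numbers.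

The compounds shown leave open how a methoxy group, a nitrile or an amine would compare with fluoro and chloro at these places. Also open, going by these compounds, is how an amide in place of the carboxylic acid would read.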